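Taking one methyl group off compound 1

This account rests on a few compounds, and the source may have more. Where it says the series, first, only, none or still open, it means among the compounds named here.

In a physicochemical assay for solubility, at pH 6.8 (a higher number here means a more soluble compound, a lower number a less soluble compound), compound 1 `Cn1cc(C(=O)N2CCN(C(=O)c3ccc(Br)cn3)[C@@H](c3ccc(Cl)cc3)C2)cc(-c2cccc(C#N)c2)c1=O` gives 12 ug/mL as its reading. Compound 2 `O=C(c1c[nH]c(=O)c2ccccc12)N1CCN(C(=O)c2ccc(Br)cc2)[C@@H](c2ccc(Cl)cc2)C1` at 11 ug/mL lies within the scatter of that number, while compound 3 `Cn1cc(C(=O)N2CCN(C(=O)c3ccc(Br)cn3)[C@@H](c3ccc(Cl)cc3)C2)cc(-c2cccc(C(F)(F)F)c2)c1=O` at 32 ug/mL reads higher than compound 1 by more than the scatter.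

Compound 4 `N#Cc1cccc(-c2cc(C(=O)N3CCN(C(=O)c4ccc(Br)cn4)[C@@H](c4ccc(Cl)cc4)C3)c[nH]c2=O)c1` departs from compound 1 in one place: hydrogen in place of methyl on an aromatic nitrogen. Among the compounds with values here, only one measured step offers any guide, and a loose one: a 2.7-fold higher number from compound 1 to compound 3 (0.43 log units; beyond the scatter) is a modest move, and it involves trifluoromethyl in place of cyano on an aromatic carbon, not this methyl. No measurement here shows what the methyl does on its own, so no step beyond the scatter is expected. The estimated step is a 1.2-fold lower number from compound 1 to compound 4 (0.08 log units; within the scatter), a slight lean towards a lower number with no direct measurement behind it. For compound 4 the estimated solubility is 10 ug/mL, with an expected range from 4 ug/mL to 25 ug/mL on repeated measurement.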

Compound 4, solubility: 2.4 ug/mL
Beside the measured number, compound 4's estimate is 4.2-fold (0.62 log units) above it, outside the stated range (below it).
By their numbers in this assay, from the lowest: compound 4; then compounds 2 and 1 (each within the scatter of the next); then compound 3.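

In this assay, the methyl on the aromatic nitrogen turns out to matter: hydrogen in its place gives a 5.0-fold lower number from compound 1 to compound 4 (0.70 log units; beyond the scatter). The earlier compounds could not show this, as the only listed step among them changed an aromatic carbon substituent and left this methyl in place. The change is small in atom count, since the group that leaves is 1 heavy atom with no ring and no net charge, yet nothing available here explains the lower reading.

From the compounds shown here alone, it remains open whether an ethyl group, a longer chain or a chain ending in an amine on the same nitrogen would read like the methyl or like the hydrogen. Going by these compounds, it also remains open whether removing this methyl would give a similar step in compound 3, which carries trifluoromethyl instead of the nitrile.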